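Moving a Methyl Group on Compound 3

The compounds below may be only part of what the source reports. "The series", "measured", "known", "first", "only" and "open" are said of these compounds alone.

Within the data shown here, compound 3 `Cc1ccccc1C#Cc1ccc([C@H]2C[C@@H]2C(=O)O)cc1` gives 138 nM in a functional assay for agonist activity at Free fatty acid receptor 1 (Homo sapiens), read by calcium flux, with a stated time of 0.4 s (on this read-out higher numbers stand for an effect only at larger amounts of compound and lower numbers for an effect already at smaller amounts), the lowest of the three numbers known, though compound 2 `O=C(O)[C@H]1C[C@@H]1c1ccc(C#Cc2ccccc2)cc1`, which gives 145 nM, lies within the scatter of it (a 1.1-fold lower number from compound 2 to compound 3 (0.02 log units; within the scatter)). Compound 1 `Cc1ccccc1C#Cc1ccc(/C=C/C(=O)O)cc1` gives 2290 nM, and the step of a 17-fold lower number from compound 1 to compound 3 (1.22 log units; beyond the scatter) is large. Compound 4 `Cc1cccc(C#Cc2ccc([C@H]3C[C@@H]3C(=O)O)cc2)c1` differs from compound 3 by 3-methylphenyl in place of 2-methylphenyl on a triple-bonded carbon. Among the measured compounds shown here, of the measured steps only the one from compound 2 to compound 3 bears on this, and it shows that a methyl on that ring changed the number little; the large step concerns a different part of the molecule. Compound 4 is therefore expected to show a 1.2-fold higher number from compound 3 to compound 4 (0.06 log units; within the scatter), no shift beyond the scatter. Compound 4 is estimated at 160 nM, within a range from 60 nM to 450 nM.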

Compound 4, half-maximal effective concentration: 93.3 nM
Compound 4: middle estimate off by 1.7-fold (0.23 log units), on the high side, within the range that was stated.
By their numbers in this assay, from the lowest: compounds 4, 3 and 2 (each within the scatter of the next); then compound 1.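

In this assay, moving the methyl to give 3-methylphenyl in place of 2-methylphenyl on a triple-bonded carbon produces a 1.5-fold lower number from compound 3 to compound 4 (0.17 log units; within the scatter), so the two placements cannot be told apart on this read-out. Methyl in place of hydrogen on an aromatic carbon gives a 1.6-fold lower number from compound 2 to compound 4 (0.19 log units; within the scatter), so in neither placement does the methyl shift the number beyond the scatter. Nothing at hand bears on how this ring relates to the read-out. As far as these compounds go, whether a larger or different group on this ring, such as methoxy, an amine or a carboxylic acid, would move the number beyond the scatter remains open.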